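Furan in place of fluorophenyl: cytotoxicity on the shared core

The source may report more compounds than this note shows. Statements on the series, on what has been measured and on what is new or still open speak of the compounds shown alone.

Compound 3 `CCOC(=O)c1c(C)[nH]c(=O)c(C#N)c1-c1ccc(F)cc1` holds the lowest number of the three measured in an ADME assay on MRC5 cells (Homo sapiens) for cytotoxicity, read by MTT assay, with a stated time of 24 h (on this read-out lower numbers stand for stronger inhibition and higher numbers for weaker inhibition), giving 149000 nM. Compound 2 `CCOC(=O)c1c(C)[nH]c(=O)c(C#N)c1-c1ccc(C#N)cc1` gives 1220000 nM in this assay and compound 1 `CCOC(=O)c1c(C)[nH]c(=O)c(C#N)c1-c1ccc([N+](=O)[O-])cc1` gives 2230000 nM; both steps to compound 3 lie beyond the scatter: a 15-fold lower number from compound 1 to compound 3 (1.18 log units; beyond the scatter) and an 8.2-fold lower number from compound 2 to compound 3 (0.91 log units; beyond the scatter), while a 1.8-fold lower number from compound 1 to compound 2 (0.26 log units; within the scatter) stays within it.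

Compound 4 `CCOC(=O)c1c(C)[nH]c(=O)c(C#N)c1-c1ccco1` is the next step: furan-2-yl in place of 4-fluorophenyl on an aromatic carbon. Among the measured compounds shown here, none of the measured steps changes the ring itself; all three exchange only the group para on the phenyl ring, and their sizes run from within the scatter to large. For the measured compounds named here, the replacement of the whole ring by furan-2-yl has no measured counterpart, so the direction rests on the spread seen so far rather than on a matching step. A modest move toward a higher number is expected, since the measured variations at this position mostly gave higher numbers than compound 3 shows at 149000 nM.

For compound 4 the expected step is a 2.3-fold higher number from compound 3 to compound 4 (0.37 log units; beyond the scatter). Compound 4 is estimated at 350000 nM in this assay, within 80000 nM to 1500000 nM.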

Compound 4, half-maximal inhibitory concentration: 407000 nM
Estimate against measurement, compound 4: 1.2-fold (0.07 log units) below; the measured number falls inside the stated range.
By their numbers in this assay, from the lowest: compound 3; then compound 4; then compounds 2 and 1 (each within the scatter of the next).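

Exchanging the whole ring at this position, rather than only the group carried on the phenyl ring, gives a 2.7-fold higher number from compound 3 to compound 4 (0.44 log units; beyond the scatter) in this assay with furan-2-yl in place of 4-fluorophenyl. The smaller five-membered ring with its one hetero atom does not take the number as high as the two phenyl compounds with nitrile or nitro groups: compound 4 at 407000 nM stands under compound 2 at 1220000 nM and compound 1 at 2230000 nM in this series. No measurement available here bears on the reason for this step.

Still open, going by these compounds, is whether a phenyl ring carrying an amine or a carboxylic acid would fall nearer compound 3 or compound 1. Also open, on these data alone, is how a saturated ring such as cyclohexyl, or a plain ethyl chain, would compare with furan-2-yl at this position.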